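A methyl swap where only limits are known

A few compounds are considered here, and "the series" means these few. Any claim that something is new, unique, unknown or untested is made for them only; others in the source may bear on it.

Measured so far:
compound 1 `OC[C@H]1O[C@@H](n2cnc3c(NCc4ccccc4Cl)ncnc32)[C@H](O)[C@@H]1O`: > 166000 nM
compound 2 `OC[C@H]1O[C@@H](n2cnc3c(NCc4cccc(Br)c4)ncnc32)[C@H](O)[C@@H]1O`: > 166000 nM

In a functional assay on B16 cells (Mus musculus) for antiproliferative activity, with a stated time of 72 h (on this read-out lower numbers stand for stronger inhibition and higher numbers for weaker inhibition), compound 1 gives > 166000 nM, which is a limit of the assay and not a number. Compound 2 gives > 166000 nM, again a limit. So compound 1 has no exact position on the scale, and what the data hold so far is the limit of > 166000 nM in this assay, at which 2 of the 2 values shown sit.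

The unmeasured compound 3 `Cc1cccc(CNc2ncnc3c2ncn3[C@@H]2O[C@H](CO)[C@@H](O)[C@H]2O)c1` keeps the core of compound 1 and carries 3-methylphenyl in place of 2-chlorophenyl on a saturated chain carbon bound to a nitrogen on an aromatic ring.

Among the measured compounds shown here, one measured step bears on this, since it changes the group at the same place: a step that the two limits leave unreadable from compound 1 to compound 2. It has no readable size, so it offers no sign of a gain or a loss. No step beyond the scatter is therefore expected in this assay, and a further limit is the likeliest report. The expected step is a step that the limit leaves unreadable from compound 1 to compound 3. The estimate for compound 3 is 180000 nM, with an expected range from 80000 nM to 400000 nM.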

Compound 3, half-maximal inhibitory concentration: > 166000 nM
Compound 3: no number, only a limit (the forecaster's own chance of this, stated with the estimate: 85%); the middle value is on the limit's open side.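

In this assay, compound 3 gives > 166000 nM, which is a limit of the assay and not a number. The steps among compound 1, compound 2 and compound 3 therefore cannot be read, and all three stand together: the limit of > 166000 nM in this assay, at which 3 of the 3 values shown sit.

As far as these compounds go, whether 2-chlorophenyl, 3-bromophenyl and 3-methylphenyl differ at all in their effect on these cells stays open.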